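Longer chain on the ester of compound 2

The compounds below may be only part of what the source reports. "The series", "measured", "known", "first", "only" and "open" are said of these compounds alone.

In a functional assay on RKO cells (Homo sapiens) for inhibition, read by MTT assay, with a stated time of 48 h (a lower number here means a stronger inhibitor, a higher number a weaker inhibitor), compound 2 (`COc1ccc(N(C)c2nc(C)nc3ccccc23)cc1C(=O)OCCC[Se]C#N`) gives 1140 nM, the second highest of three numbers. Compound 1 (`COc1ccc(N(C)c2nc(C)nc3ccccc23)cc1OCCCCCC[Se]C#N`) gives 1540 nM and compound 3 (`COc1ccc(N(C)c2nc(C)nc3ccccc23)cc1OCC[Se]C#N`) gives 27 nM. Compound 4 (`COc1ccc(N(C)c2nc(C)nc3ccccc23)cc1C(=O)OCCCCCC[Se]C#N`) differs from compound 2 by a group of 6 heavy atoms (4 carbon, 1 nitrogen, 1 selenium; no ring) in place of a group of 3 heavy atoms (1 carbon, 1 nitrogen, 1 selenium; no ring), on a saturated chain carbon, three bonds along the chain from an oxygen next to a carbonyl group. The closest measured chain change is the large 57-fold lower number from compound 1 to compound 3 (1.76 log units; beyond the scatter), where the shorter chain carries the lower number. In contrast, a 1.4-fold lower number from compound 1 to compound 2 (0.13 log units; within the scatter) stays within the scatter, so compound 2 already stands level with the longer-chain compound 1. A modest rise, far smaller than the large step, is therefore expected. The expected change is a 1.8-fold higher number from compound 2 to compound 4 (0.24 log units; within the scatter). Compound 4 is estimated at 2000 nM, with an expected range of 700 nM to 6000 nM.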

Compound 4, half-maximal inhibitory concentration: 1990 nM
Compound 4: the middle estimate sits 1.0-fold (0.00 log units) above what was measured; low and high end bracket the measured number.
By their numbers in this assay, from the lowest: compound 3; then compounds 2, 1 and 4 (each within the scatter of the next).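

In this assay, the group of 6 heavy atoms in place of the group of 3 heavy atoms on the ester chain gives a 1.7-fold higher number from compound 2 to compound 4 (0.24 log units; within the scatter), so this chain change has no readable effect at these two lengths. Within the data shown here, the large chain step on the ether side, a 57-fold lower number from compound 1 to compound 3 (1.76 log units; beyond the scatter), therefore has no counterpart in this ester pair. No available evidence bears on the difference between these two chain steps.

Still open, on these data alone, is whether an ester chain shorter than that of compound 2 would approach compound 3 at 27 nM. Also open, as far as these compounds go, is how an amide in place of the ester would behave.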